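The compounds below may be only part of what the source reports. "The series", "measured", "known", "first", "only" and "open" are said of these compounds alone.

Measured in a functional assay on MIA PaCa-2 cells (Homo sapiens) for inhibition, read by MTT assay, with a stated time of 4 days; a higher number here means a weaker inhibitor, a lower number a stronger inhibitor:
- compound 1 `COc1cc(NC(C)CCCNC(=O)NNC(=O)NCCCCCO)c2ncccc2c1`: 168000 nM
- compound 2 `COc1cc(NC(C)CCCNC(=O)NN)c2ncccc2c1`: >= 250000 nM

Among the compounds with values here, only two compounds have been measured so far, and neither offers much of a foothold. Compound 2 gives >= 250000 nM, which is a limit of the assay and not a number, so it has no exact position on the scale.

The next compound, compound 3 `COc1cc(NC(C)CCCNC(=O)NNC(=O)NC(CO)(CO)CO)c2ncccc2c1`, differs from it as follows: (2-hydroxy-1,1-bis(hydroxymethyl)ethyl)carbamoyl in place of hydrogen on an amine nitrogen. This places (2-hydroxy-1,1-bis(hydroxymethyl)ethyl)carbamoyl in place of hydrogen on an amine nitrogen.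

Within the data shown here, one measured step bears on this change. Compound 1 carries (5-hydroxypentyl)carbamoyl on that amine nitrogen, and replacing it with hydrogen gives an at least 1.4-fold higher number from compound 1 to compound 2 (0.17 log units; that floor lies within the scatter). That step involves a different carbamoyl group, runs in the opposite direction and does not exceed the scatter. It therefore gives no grounds for expecting a real shift in this assay, and compound 3 is expected to remain weak, close to compound 1 at 168000 nM.

The expected change is an at least 1.2-fold lower number from compound 2 to compound 3 (0.09 log units; that floor lies within the scatter), which is no step beyond the scatter.

For compound 3 the estimate is 200000 nM, with an expected range from 90000 nM to 400000 nM.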

Compound 3, half-maximal inhibitory concentration: > 250000 nM
Compound 3: no number, only a limit (the forecaster's own chance of this, stated with the estimate: 45%); at least 1.2-fold (0.09 log units) between middle value and limit.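

In this assay compound 3 gives > 250000 nM, which is a limit of the assay and not a number. Exchanging 5-hydroxypentyl for 2-hydroxy-1,1-bis(hydroxymethyl)ethyl on the amide-type nitrogen gives an at least 1.4-fold higher number from compound 1 to compound 3 (0.17 log units; that floor lies within the scatter), so the branched group shows no readable shift beyond the scatter, and neither carbamoyl group is yet separated from the other in this assay. The step that places this group on the amine nitrogen of compound 2 cannot be read, because the values at both of its ends are limits: the limit of > 250000 nM in this assay, at which 1 of the 3 values shown sits.

Compound 1, at 168000 nM, still holds the only exact value, so the compounds shown leave open whether any group on this amine nitrogen moves the number beyond the scatter. Going by these compounds, it also remains open how a longer chain, an amine or a carboxylic acid in place of the hydroxyl-bearing groups would read in this assay.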